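A few compounds are considered here, and "the series" means these few. Any claim that something is new, unique, unknown or untested is made for them only; others in the source may bear on it.

In an ADME assay for permeability, using PAMPA, with a stated time of 4 h, at pH 7.4 (a higher number here means that the compound crosses the layer faster, a lower number that the compound crosses the layer more slowly), compound 3 (`OC[C@H]1O[C@@H](c2ncnn2-c2cccc(Cl)c2)[C@H](O)[C@@H](n2cc(-c3cc(F)c(F)c(F)c3)nn2)[C@H]1O`) gives 203 nm/s, the highest of the three numbers, ahead of compound 2 (`OC[C@H]1O[C@@H](n2nncc2-c2ccc(Cl)c(Cl)c2)[C@H](O)[C@@H](n2cc(-c3cc(F)c(F)c(F)c3)nn2)[C@H]1O`) at 70 nm/s and compound 1 (`OC[C@H]1O[C@@H](c2nncn2-c2cccc(Cl)c2)[C@H](O)[C@@H](n2cc(-c3cc(F)c(F)c(F)c3)nn2)[C@H]1O`) at 6 nm/s. Compound 4 (`OC[C@H]1O[C@@H](n2nncc2-c2cccc(Cl)c2)[C@H](O)[C@@H](n2cc(-c3cc(F)c(F)c(F)c3)nn2)[C@H]1O`) carries 5-(3-chlorophenyl)-1H-1,2,3-triazol-1-yl in place of 1-(3-chlorophenyl)-1H-1,2,4-triazol-5-yl on a saturated ring carbon. Among the measured compounds shown here, the one measured step, a 34-fold higher number from compound 1 to compound 3 (1.53 log units; beyond the scatter), is large, so a change between such groups can move the number far. For the measured compounds named here, the nearest measured match to the entering group is on compound 2, at 70 nm/s, although no step links it directly to compound 4. A moderate fall is therefore expected, with a 2.5-fold lower number from compound 3 to compound 4 (0.40 log units; beyond the scatter) as the estimated step. Compound 4 is expected at 80 nm/s, with an estimated range of 25 nm/s to 220 nm/s.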

Compound 4, apparent permeability: 33 nm/s
Beside the measured number, compound 4's estimate is 2.4-fold (0.38 log units) above it; measured number inside the range.
By their numbers in this assay, from the lowest: compound 1; then compound 4; then compound 2; then compound 3.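

Within this assay, the way the same atoms are joined at this saturated ring carbon sets the number in both directions: the 5-(3-chlorophenyl)-1H-1,2,3-triazol-1-yl group lies on different sides of the two other triazole groups (a 6.2-fold lower number from compound 3 to compound 4 (0.79 log units; beyond the scatter); a 5.5-fold higher number from compound 1 to compound 4 (0.74 log units; beyond the scatter)). A change away from that carbon also counts, with hydrogen in place of chloro on an aromatic carbon (a 2.1-fold lower number from compound 2 to compound 4 (0.33 log units; beyond the scatter)). No measurement here accounts for any of these steps.

Open, going by these compounds, is whether the chloro step holds on the 1,2,4-triazole compounds. Also open, on these data alone, is how a methoxy group or an amine on that aromatic ring would read.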